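Methyl on the aromatic nitrogen: compound 3 to compound 4

The source may report more compounds than this note shows. Statements on the series, on what has been measured and on what is new or still open speak of the compounds shown alone.

Three compounds of the series have numbers in a functional assay on DU-145 cells (Homo sapiens) for cytotoxicity; on this read-out lower numbers stand for stronger inhibition and higher numbers for weaker inhibition. Compound 1 `Cn1cc(C(=O)N/N=C\c2cn(Cc3ccc(Cl)cc3)c3cc(F)ccc23)c2ccccc21` gives 84200 nM. Compound 2 `COc1ccc(Cn2cc(/C=N\NC(=O)c3c[nH]c4ccc(Br)cc34)c3ccc(F)cc32)cc1` gives 67500 nM. Compound 3 `COc1ccc(Cn2cc(/C=N\NC(=O)c3c[nH]c4ccccc34)c3ccc(F)cc32)cc1` gives 16200 nM, the lowest of the three numbers; compound 2 stands nearest and compound 1 furthest from it. Going by the values given here, the single one-point step in the set, a 4.2-fold lower number from compound 2 to compound 3 (0.62 log units; beyond the scatter), is hydrogen in place of bromo on an aromatic carbon.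

Compound 4 `COc1ccc(Cn2cc(/C=N\NC(=O)c3cn(C)c4ccccc34)c3ccc(F)cc32)cc1` differs from compound 3 by methyl in place of hydrogen on an aromatic nitrogen. Among the compounds with values here, no measured step covers this change on its own. Within the data shown here, compound 1 carries the same methyl on its aromatic nitrogen, but also chloro in place of methoxy on the benzyl ring, so its value and that of compound 3 show only that the two changes together end at the highest number of the set. With nothing cleaner to lean on, a moderate rise in this assay is expected, in the direction of compound 1, though it may not clear the scatter. Compound 4 is expected to give 35000 nM, within 12000 nM to 100000 nM. The expected step is a 2.2-fold higher number from compound 3 to compound 4 (0.33 log units; beyond the scatter).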

Compound 4, half-maximal inhibitory concentration: 15200 nM
For compound 4 the middle estimate is 2.3-fold (0.36 log units) above the measured one, within the range that was stated.
By their numbers in this assay, from the lowest: compounds 4 and 3 (each within the scatter of the next); then compounds 2 and 1 (each within the scatter of the next).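

In this assay, methyl in place of hydrogen on the aromatic nitrogen of the 1H-indol-3-yl group gives a number that cannot be told apart from that of the parent (a 1.1-fold lower number from compound 3 to compound 4 (0.03 log units; within the scatter)), so in this pair the hydrogen on that nitrogen makes no measurable difference. With the methyl now present on both sides, the step to methoxy from chloro on an aromatic carbon can be read on its own (a 5.5-fold lower number from compound 1 to compound 4 (0.74 log units; beyond the scatter)), and the high number of compound 1 goes with the chloro and not with the methyl. The step from the 5-bromo-1H-indol-3-yl group to the 1-methyl-1H-indol-3-yl group (a 4.4-fold lower number from compound 2 to compound 4 (0.65 log units; beyond the scatter)) therefore fits a rise carried by the bromo, while the methyl adds nothing that can be detected.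

No measurement available here accounts for any of these steps.

Open, going by these compounds, is whether this nitrogen tolerates more than methyl, such as an ethyl, a longer chain or an acetyl group. Also open, on these data alone, is whether the bromo and chloro steps hold on the other form of the nitrogen, with hydrogen or methyl there.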